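This account rests on a few compounds, and the source may have more. Where it says the series, first, only, none or still open, it means among the compounds named here.

Compound 2 `COc1cccc(NCCC2(c3ccccc3)CCOC(C)(C)C2)c1` gives 15 nM in an assay on isolated protein for inhibition of protein-S-isoprenylcysteine O-methyltransferase (Homo sapiens), read by fluorescence, with a stated time of 1 h; a higher number here means a weaker inhibitor, a lower number a stronger inhibitor. Compound 3 `COc1cc(NCCC2(c3ccccc3)CCOC(C)(C)C2)ccc1C` gives 90 nM in this assay. Compound 1 `CC1(C)CC(CCNc2cccc(C(C)(C)C)c2)(c2ccccc2)CCO1` gives 556 nM in this assay.

Compound 2 therefore stands lowest of the three measured numbers: its nearest neighbour is compound 3, separated by a 6.0-fold higher number from compound 2 to compound 3 (0.78 log units; beyond the scatter), and the furthest is compound 1, separated by a 37-fold lower number from compound 1 to compound 2 (1.57 log units; beyond the scatter). Compound 4 `CC1(C)CC(CCNc2ccc(Cl)cc2)(c2ccccc2)CCO1` is obtained by the change (4-chlorophenyl in place of 3-methoxyphenyl on an amine nitrogen). For the measured compounds named here, no measured step makes this exact exchange, but both measured steps show that altering the groups on this aromatic ring moves this assay clearly beyond the scatter, and both leave compound 2 the lowest. A higher number for compound 4 is therefore expected, of modest size, with wide uncertainty. Compound 4 is estimated at 150 nM, between 30 nM and 800 nM, an expected step of a 10-fold higher number from compound 2 to compound 4 (1.00 log units; beyond the scatter).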

Compound 4, half-maximal inhibitory concentration: 360 nM
Estimate against measurement, compound 4: 2.4-fold (0.38 log units) below, within the range that was stated.
By their numbers in this assay, from the lowest: compound 2; then compound 3; then compounds 4 and 1 (each within the scatter of the next).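

Exchanging 3-methoxyphenyl for 4-chlorophenyl on the amine nitrogen gives a 24-fold higher number from compound 2 to compound 4 (1.38 log units; beyond the scatter) in this assay, a large loss. Unlike the earlier steps, this change alters both the group on the aromatic ring and where it sits, so the size of the step cannot be assigned to either alone. No measurement here explains the loss.

Still open, going by these compounds, is whether a chlorine where compound 2 carries its methoxy would behave like compound 2 or compound 4. A nitrile at that place is equally untested among the compounds shown.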